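Methoxyphenyl for Dichlorophenyl on a Quinoline Sulfone

The source may hold more compounds than are shown below. What is called first, only, known or untested is meant among the compounds shown, and "the series" means these compounds.

Compound 1 `COc1ccc(S(=O)(=O)c2cnc3ccc(OC)cc3c2N2CCC(C)CC2)cc1`: 41%
Compound 2 `COc1ccc2ncc(S(=O)(=O)c3ccc(Cl)c(Cl)c3)c(N3CCC(C)CC3)c2c1`: 87%
Compound 3 `CC1CCN(c2c(S(=O)(=O)c3ccc(Cl)c(Cl)c3)cnc3cc(Cl)ccc23)CC1`: 89%

Of the compounds shown here, three have been measured in an assay on isolated protein for displacement of a labelled ligand from metabotropic glutamate receptor 5 (Homo sapiens), with a stated time of 60 min, tested at 1 uM; on this read-out lower numbers stand for less inhibition and higher numbers for more inhibition at the one concentration tested (going by the name of the read-out). Compound 2 gives 87% and compound 3 gives 89%; these two values lie within the scatter of each other, so nothing separates them. Compound 1, by contrast, gives 41%, well apart from both. Compound 1 and compound 2 differ in one place, (4-methoxyphenyl in place of 3,4-dichlorophenyl on a sulfonyl sulfur), and this change made a step of a number 46 percentage points lower from compound 2 to compound 1 (beyond the scatter).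

Compound 2 and compound 3 share the same sulfonyl-linked 3,4-dichlorophenyl group and the same piperidine, but the difference between their two cores is not broken down here.

Compound 4 `COc1ccc(S(=O)(=O)c2cnc3cc(Cl)ccc3c2N2CCC(C)CC2)cc1` is not yet measured. It stands to compound 3 as compound 1 stands to compound 2: 4-methoxyphenyl in place of 3,4-dichlorophenyl on a sulfonyl sulfur. The place lines of the two changes read the same word for word, so the change is the same kind of change on the core of compound 3 that was already seen on the core of compound 2. If the step repeats, compound 4 is expected to fall from compound 3 by about a number 46 percentage points lower from compound 3 to compound 4 (beyond the scatter), which rests on the single measured step of a number 46 percentage points lower from compound 2 to compound 1 (beyond the scatter). Among the compounds with values here, only one such step is known. Compound 3 and compound 2 differ in their cores in a way that is not broken down here. The expectation therefore carries a wide band. Compound 4 is therefore estimated at 43% in this assay, with a range from 25% to 62%.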

Compound 4, a percentage reported as inhibition, at one concentration (the size of the read-out at that concentration, not a potency): 79%
Compound 4: the middle estimate sits 36 percentage points below what was measured; the measured number lies above the stated range.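

In this assay, putting 4-methoxyphenyl in place of 3,4-dichlorophenyl on a sulfonyl sulfur gave a number 10 percentage points lower from compound 3 to compound 4 (within the scatter), so compound 3 and compound 4 cannot be told apart on this read-out. The change therefore did not carry over from the core of compound 2 to the core of compound 3 with the same size, and a step measured on one core in this series cannot simply be transferred to the other: the same change on two cores in this assay, a number 46 percentage points lower (beyond the scatter) from compound 2 to compound 1 and a number 10 percentage points lower (within the scatter) from compound 3 to compound 4, 36 percentage points apart, beyond the scatter of two such steps. This shows that the outcome of the change depends on the core it is made on, but it rests on one pair per core and does not show which part of the difference between the two cores is responsible, nor how the compounds would compare at any other concentration.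

Within the data shown here, still open is whether a further core would follow the step seen with compound 2 and compound 1 or the one seen with compound 3 and compound 4. All the compounds shown also keep the same piperidine, so it remains unknown how the change would behave with a morpholine in its place, or with a carboxylic acid or an amide on the ring carried by the sulfonyl sulfur.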